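Aryl swap on the longest-chain amide of the series

The source may hold more compounds than are shown below. What is called first, only, known or untested is meant among the compounds shown, and "the series" means these compounds.

Measured in a functional assay on MCF7 cells (Homo sapiens) for cytotoxicity, read by MTT assay, with a stated time of 48 h; a lower number here means a stronger inhibitor, a higher number a weaker inhibitor:
compound 1 `CCCCCCCCCCCCNC(=O)[C@@H](NC(=O)c1nccc2ccccc12)[C@@H](C)O` gives 50500 nM
compound 2 `CCCCCCCCCCCCCCNC(=O)[C@@H](NC(=O)c1nccc2ccccc12)[C@@H](C)O` gives 22800 nM
compound 3 `CCCCCCCCCCCCCCCCCCNC(=O)[C@@H](NC(=O)c1cc2ccccc2o1)[C@@H](C)O` gives 126000 nM

Compound 3 stands highest of the three numbers, beyond the scatter from both compound 1 and compound 2, with compound 2 furthest from it. Compound 4 `CCCCCCCCCCCCCCCCCCNC(=O)[C@@H](NC(=O)c1nccc2ccccc12)[C@@H](C)O` differs from compound 3 by isoquinolin-1-yl in place of 1-benzofuran-2-yl on a carbonyl carbon. Within the data shown here, no measured pair isolates this change; compound 3 and compound 2 differ in both the aryl group and the chain, so their values show only the combined gap. Among the measured compounds shown here, the single measured step, a 2.2-fold lower number from compound 1 to compound 2 (0.35 log units; beyond the scatter), concerns chain length alone. Compound 4 shares its aryl group with compound 1 and compound 2 and is therefore expected near them, well off compound 3. The step is expected to read a 4.2-fold lower number from compound 3 to compound 4 (0.62 log units; beyond the scatter), with wide uncertainty. Compound 4 is estimated at 30000 nM, range 8000 nM to 120000 nM.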

Compound 4, half-maximal inhibitory concentration: 30800 nM
Estimate against measurement, compound 4: 1.0-fold (0.01 log units) below, and the stated range covers the measured number.
By their numbers in this assay, from the lowest: compounds 2, 4 and 1 (each within the scatter of the next, the first and the last beyond it); then compound 3.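

In this assay, among these compounds, isoquinolin-1-yl in place of 1-benzofuran-2-yl on a carbonyl carbon gives a 4.1-fold lower number from compound 3 to compound 4 (0.61 log units; beyond the scatter), the first reading of this aryl change with the chain held constant. Among the compounds shown here, with isoquinolin-1-yl held, the chain steps a 1.4-fold higher number from compound 2 to compound 4 (0.13 log units; within the scatter) and a 1.6-fold lower number from compound 1 to compound 4 (0.21 log units; within the scatter) show compound 4 level with compound 1 and compound 2, although a 2.2-fold lower number from compound 1 to compound 2 (0.35 log units; beyond the scatter) stays the one chain step beyond the scatter. No evidence bears on the origin of the aryl step.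

Going by these compounds, whether the aryl step holds at the shorter chains of compound 1 and compound 2 remains open. Also open, on these data alone, is how an amine or carboxylic acid at the chain end, or a chain longer than that of compound 4, would read.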